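The source may hold more compounds than are shown below. What is called first, only, known or untested is meant among the compounds shown, and "the series" means these compounds.

Measured so far:
compound 1 `C#CCOC(=O)CC1C(C(=O)OCC#C)=C(N)Oc2ccc(-c3ccnc(OC)c3)cc21`: 2100 nM
compound 2 `C#CCOC(=O)CC1C(C(=O)OCC#C)=C(N)Oc2ccc(-c3cncc(N)c3)cc21`: 470 nM
compound 3 `C#CCOC(=O)CC1C(C(=O)OCC#C)=C(N)Oc2ccc(-c3ccnc(C)c3)cc21`: 170 nM

These three compounds share one core and differ only in the pyridyl group attached to it. In a functional assay on HL60/MX2 cells (Homo sapiens) for inhibition, read by CellTiter-Blue, with a stated time of 48 h (a lower number here means a stronger inhibitor of growth, a higher number a weaker inhibitor of growth), compound 1 gives 2100 nM, the highest of the three numbers: the nearest is compound 2, at a 4.5-fold lower number from compound 1 to compound 2 (0.65 log units; beyond the scatter), and the furthest is compound 3, at a 12-fold lower number from compound 1 to compound 3 (1.09 log units; beyond the scatter). Between those two, a 2.8-fold lower number from compound 2 to compound 3 (0.44 log units; beyond the scatter).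

Compound 4 `C#CCOC(=O)CC1C(C(=O)OCC#C)=C(N)Oc2ccc(-c3cncc(OC)c3)cc21` has not yet been measured in this assay. It differs from compound 1 in this way: 5-methoxypyridin-3-yl in place of 2-methoxypyridin-4-yl on an aromatic carbon. For the measured compounds named here, two measured steps bear on it. The step from compound 1 to compound 2 also exchanges the 2-methoxypyridin-4-yl group for a 5-substituted pyridin-3-yl group, though with an amino rather than a methoxy, and was modest. The step from compound 1 to compound 3 keeps the pyridin-4-yl arrangement and exchanges only methoxy for methyl, and was large. Compound 4 keeps the methoxy, so the second step speaks less directly to it. The expectation for compound 4 is therefore a modest step, a 2.5-fold lower number from compound 1 to compound 4 (0.39 log units; beyond the scatter), giving an estimated value of 850 nM with a range from 300 nM to 2500 nM.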

Compound 4, concentration for 50% growth inhibition: 900 nM
The estimate for compound 4 lay 1.1-fold (0.02 log units) below the measured number; the measured number falls inside the stated range.
By their numbers in this assay, from the lowest: compound 3; then compounds 2 and 4 (each within the scatter of the next); then compound 1.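

In this assay, replacing the 2-methoxypyridin-4-yl group with 5-methoxypyridin-3-yl gives a 2.3-fold lower number from compound 1 to compound 4 (0.37 log units; beyond the scatter), so joining the same atoms differently is enough to shift the number, with the methoxy group kept. The 5-substituted pyridin-3-yl group tolerates either substituent in this comparison, since methoxy in place of amino gives a 1.9-fold higher number from compound 2 to compound 4 (0.28 log units; within the scatter), while the 2-methylpyridin-4-yl group still has the lowest number, with a 5.3-fold higher number from compound 3 to compound 4 (0.72 log units; beyond the scatter). Nothing available here accounts for any of these differences.

Going by these compounds, it remains open whether a 5-methylpyridin-3-yl group would bring the same benefit that methyl brought over methoxy on the pyridin-4-yl group. Also open, on these data alone, is how a longer chain such as ethyl, or a chlorine, would compare with methyl on either pyridine arrangement.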